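Shrinking the Ring on the Amino Nitrogen Again

This account rests on a few compounds, and the source may have more. Where it says the series, first, only, none or still open, it means among the compounds named here.

In a functional assay on HCT-116 cells (Homo sapiens) for antiproliferative activity, read by MTT assay, with a stated time of 72 h (on this read-out higher numbers stand for weaker inhibition and lower numbers for stronger inhibition), compound 1 (`O=C(Nc1ccc(Nc2nccc(NC3CCCCC3)n2)cc1)Nc1ccc(Cl)c(C(F)(F)F)c1`) gives 5950 nM while compound 2 (`O=C(Nc1ccc(Nc2nccc(NC3CCCC3)n2)cc1)Nc1ccc(Cl)c(C(F)(F)F)c1`) gives 2510 nM on the same read-out. Compound 2 therefore holds the lower of the two numbers and is the stronger inhibitor of this pair. Compound 3 (`O=C(Nc1ccc(Nc2nccc(NC3CC3)n2)cc1)Nc1ccc(Cl)c(C(F)(F)F)c1`) keeps the shared core and changes a single group (cyclopropyl in place of cyclopentyl on a nitrogen on an aromatic ring), with cyclopropyl in place of cyclopentyl on a nitrogen on an aromatic ring. Within the data shown here, the one measured step that bears on this change is a 2.4-fold lower number from compound 1 to compound 2 (0.37 log units; beyond the scatter) and it came from swapping cyclohexyl for cyclopentyl at that same place. It is modest, though beyond the scatter, and a single step cannot establish a trend. A small further fall in this assay is therefore expected, but one that probably stays within the scatter, and a rise remains possible. The expected step is a 1.3-fold lower number from compound 2 to compound 3 (0.10 log units; within the scatter) on this thin evidence. The estimate for compound 3 is 2000 nM with an expected range from 700 nM to 6000 nM once it is measured.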

Compound 3, half-maximal inhibitory concentration: 16400 nM
The estimate for compound 3 lay 8.2-fold (0.91 log units) below the measured number; the measured number lies above the stated range.
By their numbers in this assay, from the lowest: compound 2; then compound 1; then compound 3.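

The number in this assay does not keep falling as the ring on the amino nitrogen shrinks. The first reduction in ring size brought a modest gain (a 2.4-fold lower number from compound 1 to compound 2 (0.37 log units; beyond the scatter)), but replacing cyclopentyl with cyclopropyl reverses it (a 6.5-fold higher number from compound 2 to compound 3 (0.82 log units; beyond the scatter)), and the smallest ring ends up weaker even than the largest (a 2.8-fold higher number from compound 1 to compound 3 (0.44 log units; beyond the scatter)). Of these three compounds, compound 2 is therefore the strongest inhibitor, with both a larger and a smaller carbon ring giving higher numbers, although nothing available explains why the five-membered ring does best.

On these data alone, these three rings give only a coarse view of this position, so it remains open how sharply activity changes around cyclopentyl, and whether cyclobutyl would sit closer to compound 2 or to compound 3. As far as these compounds go, it is also open whether a ring is needed at all, which an open-chain group such as isopropyl could test, and whether a ring carrying a hydroxyl group or a ring nitrogen, as in piperidine, would be tolerated on this amino nitrogen.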